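Configuration Change at Two Stereo Elements in a Hydroxyamide Series

The source may report more compounds than this note shows. Statements on the series, on what has been measured and on what is new or still open speak of the compounds shown alone.

Measured compounds:
compound 1, `CCOC(=O)/C=C/NC(=O)[C@H](O)C(C)(C)CO`, 36%
compound 2, `CC(C)(C)OC(=O)/C=C/NC(=O)[C@H](O)C(C)(C)CO`, 0%
compound 3, `COC(=O)/C=C\NC(=O)[C@@H](O)C(C)(C)CO`, -20%

Of the compounds shown here, three have been tested in an ADME assay on WI-38 cells (Homo sapiens) for inhibition, read by CellTiter-Glo, with a stated time of 48 h, tested at 100 uM; a lower number here means less inhibition, a higher number more inhibition at the concentration tested (going by the name of the read-out). Compound 1, `CCOC(=O)/C=C/NC(=O)[C@H](O)C(C)(C)CO`, gives 36%. For the measured compounds named here, compound 2, `CC(C)(C)OC(=O)/C=C/NC(=O)[C@H](O)C(C)(C)CO`, gives 0%, and the only step recorded between measured compounds is a number 36 percentage points lower from compound 1 to compound 2 (beyond the scatter). Compound 3, `COC(=O)/C=C\NC(=O)[C@@H](O)C(C)(C)CO`, gives -20% and stands lowest of the three: its number lies beyond the scatter below compound 2 and further still below compound 1.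

The next compound, compound 4, `COC(=O)/C=C/NC(=O)[C@H](O)C(C)(C)CO`, is to be measured in this assay. It differs from compound 3 in this way: the two compounds have the same atoms and bonds and differ only in configuration as drawn: 2 of 2 stereo elements differ; a stereocentre at a saturated chain carbon is drawn S in compound 3 and R in compound 4; a double bond is drawn Z in compound 3 and E in compound 4. Going by the values given here, no measured step concerns a change of configuration, so the single recorded step, a number 36 percentage points lower from compound 1 to compound 2 (beyond the scatter), which concerns the ester group, does not bear on it directly. Compound 4 does share its configuration as drawn with compound 1 and compound 2, whose numbers both sit above compound 3, which hints at a move upward, but the evidence is thin. Compound 4 is therefore expected to move by a number 35 percentage points higher from compound 3 to compound 4 (beyond the scatter), with a wide range. The estimate for compound 4 is 15%, between -15% and 45%.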

Compound 4, a percentage reported as inhibition, at one concentration (the size of the read-out at that concentration, not a potency): 4%
Estimate against measurement, compound 4: 11 percentage points above; measured number inside the range.
By their numbers in this assay, from the lowest: compound 3; then compounds 2 and 4 (each within the scatter of the next); then compound 1.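

In this assay the first step that concerns configuration is a number 24 percentage points higher from compound 3 to compound 4 (beyond the scatter), and it can be ascribed to configuration as drawn alone because nothing else separates the pair: the fact that compounds 3 and 4 differ only in the configuration as drawn

With the configuration held as in compound 1, the series also gains a methyl ester for comparison with the other two esters: a number 4 percentage points higher from compound 2 to compound 4 (within the scatter), so methyl and tert-butyl on that oxygen cannot be told apart here, whereas a number 32 percentage points lower from compound 1 to compound 4 (beyond the scatter). Ethyl therefore stands alone among these three esters, and the numbers do not rise or fall steadily from methyl through ethyl to tert-butyl.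

Which of the two stereo elements carries the configurational step stays open, as the compounds shown offer no pair in which the stereocentre changes without the double bond, or the double bond without the stereocentre. Also open, as far as these compounds go, is whether the higher number seen with ethyl extends to a longer chain on that oxygen, or what a carboxylic acid in place of the ester would give.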